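Trading a Trifluoromethyl for a Bromo on the Benzyl Ring

This account rests on a few compounds, and the source may have more. Where it says the series, first, only, none or still open, it means among the compounds named here.

Three compounds from a sulfonamide series have been measured in a functional assay on ASPC1 cells (Homo sapiens) for inhibition, read by MTT assay, with a stated time of 72 h; a lower number here means a stronger inhibitor of growth, a higher number a weaker inhibitor of growth:

Compound 1, `O=S(=O)(NCCCNCc1ccc(Cl)cc1)c1cc(C(F)(F)F)cc(C(F)(F)F)c1`, gives 3000 nM.
Compound 2, `O=S(=O)(NCCNCc1ccc(-c2ccccc2)cc1)c1cc(C(F)(F)F)cc(C(F)(F)F)c1`, gives 2800 nM.
Compound 3, `O=S(=O)(NCCCNCc1ccc(C(F)(F)F)cc1)c1cc(C(F)(F)F)cc(C(F)(F)F)c1`, gives 2000 nM.

Compound 3 has the lowest of the three numbers, yet its gaps to compound 2 and to compound 1 both lie within the usual scatter, so none of the three can be set apart from the others on these numbers.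

Compound 4, `O=S(=O)(NCCCNCc1ccc(Br)cc1)c1cc(C(F)(F)F)cc(C(F)(F)F)c1`, is the next compound to be tested. Compared with compound 3 the change is bromo in place of trifluoromethyl on an aromatic carbon.

Among the compounds with values here, only one measured step speaks to this kind of exchange at that position: a 1.5-fold lower number from compound 1 to compound 3 (0.18 log units; within the scatter), a chloro-to-trifluoromethyl swap on the same benzyl ring that did not move the number beyond the scatter. Within the data shown here, there is no measured pair involving a bromo group at all. Going the other way, from trifluoromethyl to a single halogen, the nearest precedent therefore suggests little movement, and the step from compound 3 to compound 4 is expected to be a 1.3-fold higher number from compound 3 to compound 4 (0.10 log units; within the scatter), no larger than the scatter in either direction. Compound 4 is thus estimated at 2500 nM, with a likely range from 1200 nM to 5500 nM.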

Compound 4, concentration for 50% growth inhibition: 2800 nM
Compound 4: middle estimate off by 1.1-fold (0.05 log units), on the low side; the measured number falls inside the stated range.
By their numbers in this assay, from the lowest: compounds 3, 2, 4 and 1 (each within the scatter of the next).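

In this assay, bromo in place of trifluoromethyl on the benzyl ring gives a 1.4-fold higher number from compound 3 to compound 4 (0.15 log units; within the scatter), and bromo in place of chloro gives a 1.1-fold lower number from compound 1 to compound 4 (0.03 log units; within the scatter). The earlier compounds shown here offered a single exchange at this place, whereas compounds 1, 3 and 4 now show three groups there, including a swap of a 4-atom trifluoromethyl for a single bromine atom, and neither new step moves the number beyond the scatter, so these three groups cannot be put in any order. Nothing measured here accounts for this lack of separation.

From the compounds shown here alone, all three groups at this place are halogens or trifluoromethyl, so it remains open whether an amine, a carboxylic acid or a plain hydrogen there would shift the number beyond the scatter. Compound 2 differs from these three in both its chain and its ring group, which leaves the effect of each change on its own unresolved, along with whether a longer chain would change the result.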